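This account rests on a few compounds, and the source may have more. Where it says the series, first, only, none or still open, it means among the compounds named here.

Going by the values given here, compound 2 `O=C(NCCCCl)Nc1ccc(S(=O)(=O)Oc2ccccc2I)cc1` gives 2800 nM in a functional assay on HT-1080 cells (Homo sapiens) for antiproliferative activity, read by sulforhodamine B assay, with a stated time of 48 h (on this read-out lower numbers stand for stronger inhibition and higher numbers for weaker inhibition), the highest of the two numbers measured so far. Among the compounds with values here, its nearest neighbour is compound 1 `CCNC(=O)Nc1ccc(S(=O)(=O)Oc2ccccc2I)cc1`, which gives 140 nM; the only measured step, a 20-fold higher number from compound 1 to compound 2 (1.30 log units; beyond the scatter), put a chloromethyl group in place of a hydrogen on a saturated chain carbon two bonds along the chain from an amide-type nitrogen.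

Compound 3 `O=C(Nc1ccc(S(=O)(=O)Oc2ccccc2I)cc1)NC1CC1` takes the opposite route in size: cyclopropyl in place of 3-chloropropyl on an amide-type nitrogen. The cyclopropyl group that enters is close in bulk to the ethyl group of compound 1, while the chlorine and the longer chain that made compound 2 weaker leave. Within the data shown here, the one measured step therefore suggests a clear move back toward lower numbers, though no step of exactly this kind has been measured, so the size is uncertain. For compound 3 a number near that of compound 1 is expected, 250 nM within 80 nM to 900 nM, which would mean an estimated 11-fold lower number from compound 2 to compound 3 (1.05 log units; beyond the scatter).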

Compound 3, half-maximal inhibitory concentration: 1300 nM
Compound 3: middle estimate off by 5.2-fold (0.72 log units), on the low side; the whole stated range lies below it.
By their numbers in this assay, from the lowest: compound 1; then compound 3; then compound 2.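

Cyclopropyl in place of 3-chloropropyl gives a 2.2-fold lower number from compound 2 to compound 3 (0.33 log units; beyond the scatter) in this assay. Removing the chlorine-bearing chain in this way recovers only part of the ground lost between compound 1 and compound 2. Cyclopropyl in place of ethyl gives a 9.3-fold higher number from compound 1 to compound 3 (0.97 log units; beyond the scatter) and this shows that the amide-type nitrogen separates two groups that carry no chlorine, so chlorine is not needed for a large rise in the number. Of these three compounds, compound 1 with its ethyl group remains the most potent, and nothing given here explains why the ring gives a higher number than ethyl.

Still open, going by these compounds, is where a plain propyl chain without chlorine would fall relative to compound 1 and compound 2. A methyl group or a larger ring such as cyclobutyl on the same nitrogen would show how narrow the preference for ethyl is.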